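Ring enlargement on the carbonyl carbon: free fraction outlook

This account rests on a few compounds, and the source may have more. Where it says the series, first, only, none or still open, it means among the compounds named here.

In an ADME assay for protein binding, using equilibrium dialysis, at pH 7.4, tested at 2 uM (on this read-out lower numbers stand for a smaller free fraction and higher numbers for a larger free fraction), compound 1 `CC(C)N(C(=O)C1CCC(F)(F)CC1)c1cc(C#CC(C)(C)C)sc1C(=O)O` gives 0.4, and compound 2 `CC(C)N(C(=O)[C@H]1[C@@H]2CCCC[C@@H]21)c1cc(C#CC(C)(C)C)sc1C(=O)O` gives 0.04, the lower of the two numbers. Compound 3 `CC(C)N(C(=O)[C@@H]1CC[C@@H]2C[C@@H]2CC1)c1cc(C#CC(C)(C)C)sc1C(=O)O` departs from compound 2 on the same carbonyl carbon: a group of 8 heavy atoms (8 carbon; one three-membered non-aromatic ring of carbon only, one seven-membered non-aromatic ring of carbon only) in place of a group of 7 heavy atoms (7 carbon; one three-membered non-aromatic ring of carbon only, one six-membered non-aromatic ring of carbon only), on a carbonyl carbon. Among the measured compounds shown here, the only measured step at this place is a 10-fold lower number from compound 1 to compound 2 (1.00 log units; beyond the scatter), and it exchanged a fluorine-bearing group, so it is a loose guide. For the measured compounds named here, no measured step compares two groups of carbon only. The expected step is small, slightly downward and within the scatter: a 1.3-fold lower number from compound 2 to compound 3 (0.12 log units; within the scatter). The estimate for compound 3 is 0.03, with an expected range of 0.012 to 0.08.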

Compound 3, unbound fraction: 0.05
Compound 3: middle estimate off by 1.7-fold (0.22 log units), on the low side; the range from low to high includes it.
By their numbers in this assay, from the lowest: compounds 2 and 3 (each within the scatter of the next); then compound 1.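

In this assay, among the compounds shown here, the first comparison of two carbon-only groups at this place gives a 1.3-fold higher number from compound 2 to compound 3 (0.10 log units; within the scatter) and so does not separate the seven-membered from the six-membered ring, each with its three-membered ring. The fluorine-bearing group stays apart, with an 8.0-fold lower number from compound 1 to compound 3 (0.90 log units; beyond the scatter) on this read-out. No available measurement bears on the cause of these steps.

Still open, going by these compounds, is whether the fluorine atoms or the missing three-membered ring set compound 1 apart. A plain cyclohexyl group on the same carbonyl carbon would separate the two.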